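This account rests on a few compounds, and the source may have more. Where it says the series, first, only, none or still open, it means among the compounds named here.

Measured compounds:
compound 1 `Cc1cc(=O)oc2cc(SCc3cccc(C#N)c3)ccc12`: > 32500 nM
compound 2 `COC(=O)c1cccc(CSc2ccc3c(C)cc(=O)oc3c2)c1`: 2060 nM
compound 3 `Cc1cccc(CSc2ccc3c(C)cc(=O)oc3c2)c1`: > 33700 nM

In a functional assay on KB cells (Homo sapiens) for antiproliferative activity, read by sulforhodamine B assay, with a stated time of 72 h (a lower number here means a stronger inhibitor of growth, a higher number a weaker inhibitor of growth), compound 1 reaches only a limit of the assay, > 32500 nM (the limit of > 32500 nM in this assay, at which 1 of the 3 values shown sits). Compound 2 gives a number, 2060 nM. Compound 3 again reaches only a limit, > 33700 nM (the limit of > 33700 nM in this assay, at which 1 of the 3 values shown sits). For the measured compounds named here, compound 3 thus stands at a limit of this assay, as one of two limits among the three values, with compound 2 the only compound that gives a number.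

Compound 4 `Cc1cc(=O)oc2cc(SCc3cccc(OC(F)(F)F)c3)ccc12` differs from compound 3 by trifluoromethoxy in place of methyl on an aromatic carbon. The measured steps at the same place are an at least 15-fold lower number from compound 1 to compound 2 (1.19 log units; beyond the scatter) and an at least 16-fold higher number from compound 2 to compound 3 (1.21 log units; beyond the scatter); the step that the two limits leave unreadable from compound 1 to compound 3 runs between two limits. Going by the values given here, none of these steps carries the trifluoromethoxy group, so they show only that a change at this place can move this assay by a large amount in either direction. Compound 3 sits at a limit; a step toward a higher number from there would not be readable, while a step toward a lower number of the size seen from compound 1 to compound 2 is possible but unsupported by any step with this group. Compound 4 is expected near the limit, at 20000 nM with a range of 3000 nM to 60000 nM. That estimate means an expected step of an at least 1.6-fold lower number from compound 3 to compound 4 (0.22 log units; that floor lies within the scatter).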

Compound 4, concentration for 50% growth inhibition: 14800 nM
Beside the measured number, compound 4's estimate is 1.4-fold (0.13 log units) above it; low and high end bracket the measured number.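

Working notes on the series: at this place, on an aromatic carbon meta to a large group, trifluoromethoxy joins methoxycarbonyl as a second group that gives a number rather than a limit in this assay, so activity here is not confined to methoxycarbonyl. Both steps from the limit compounds show a gain that is beyond the scatter, an at least 2.2-fold lower number from compound 3 to compound 4 (0.35 log units; beyond the scatter) and an at least 2.1-fold lower number from compound 1 to compound 4 (0.34 log units; beyond the scatter), and each is only a floor, since compound 3 and compound 1 stand at limits. The group still falls short of methoxycarbonyl, with a 7.2-fold higher number from compound 2 to compound 4 (0.86 log units; beyond the scatter), which leaves compound 2 the strongest of the four in this assay and places compound 4 in an intermediate position.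

Nothing at hand bears on the cause of these steps. Open, from the compounds shown here alone, are the true sizes of the two steps from the limit compounds, whether a carboxylic acid, an amine or a longer chain at this place would match or pass methoxycarbonyl, and whether methoxycarbonyl and trifluoromethoxy keep their order on another aromatic carbon of the ring.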